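Compound 2 and its methoxy counterpart, compound 4

The compounds below may be only part of what the source reports. "The series", "measured", "known", "first", "only" and "open" are said of these compounds alone.

Measured in a functional assay on MDA-MB-231 cells (Homo sapiens) for antiproliferative activity, read by MTT assay, with a stated time of 72 h; on this read-out lower numbers stand for stronger inhibition and higher numbers for weaker inhibition:
- Compound 1 `CC1=CC[C@H]2[C@@H]1CC=C(C)[C@@H](CC[C@H]1[C@]3(C)CC[C@H](O)C(C)(C)O[C@H]3CC[C@@]1(C)O)C2(C)C`: > 50000 nM (a limit)
- Compound 2 `CC1=CC[C@H]2[C@H](CC[C@]2(C)O)C(C)(C)[C@@H]1CC[C@H]1[C@]2(C)CC[C@H](OC(=O)c3ccc(Cl)cc3)C(C)(C)O[C@H]2CC[C@@]1(C)O`: 10300 nM
- Compound 3 `CC1=CC[C@H]2[C@@H]1CC=C(C)[C@@H](CC[C@H]1[C@]3(C)CC[C@H](OC(=O)c4ccccc4)C(C)(C)O[C@H]3CC[C@@]1(C)O)C2(C)C`: 18400 nM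

Compound 1 gives > 50000 nM in this assay, which is a limit of the assay and not a number. Within the data shown here, only two compounds have true numbers. Compound 2 gives 10300 nM and compound 3 gives 18400 nM, and these two values lie within the usual scatter of each other.

The next compound is compound 4 `COc1ccc(C(=O)O[C@H]2CC[C@]3(C)[C@H](CC[C@@](C)(O)[C@H]3CC[C@@H]3C(C)=CC[C@H]4[C@H](CC[C@]4(C)O)C3(C)C)OC2(C)C)cc1`, which differs from compound 2 as follows: methoxy in place of chloro on an aromatic carbon. In words, methoxy stands in place of chloro on an aromatic carbon, para to a large group.

Among the measured compounds shown here, only one measured step is available, an at least 2.7-fold lower number from compound 1 to compound 3 (0.43 log units; beyond the scatter). It puts benzoyl in place of hydrogen on an oxygen on a saturated carbon, so it bears on the ester as a whole. For the measured compounds named here, it does not show what a change on the aromatic carbon does, and no measured pair isolates that change. Going by the values given here, with no measured step to set a size or direction, no shift beyond the scatter is expected in this assay. The expected step is a 1.4-fold higher number from compound 2 to compound 4 (0.13 log units; within the scatter). Compound 4 is estimated at 14000 nM, with an expected range from 6000 nM to 35000 nM.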

Compound 4, half-maximal inhibitory concentration: 30600 nM
Beside the measured number, compound 4's estimate is 2.2-fold (0.34 log units) below it, within the range that was stated.
By their numbers in this assay, from the lowest: compounds 2, 3 and 4 (each within the scatter of the next, the first and the last beyond it). At a limit, above all of these: compound 1.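

In this assay, the aromatic carbon para to a large group turns out to be a place where the substituent matters: with methoxy in place of chloro there is a 3.0-fold higher number from compound 2 to compound 4 (0.47 log units; beyond the scatter). The earlier step, an at least 2.7-fold lower number from compound 1 to compound 3 (0.43 log units; beyond the scatter), put benzoyl in place of hydrogen on an oxygen and so spoke only of the ester as a whole, on the core of compound 1, whereas this step isolates a single substituent on the aromatic ring of the ester, on the core of compound 2, and shows that chloro and methoxy are not interchangeable there, with the 4-chlorophenyl ester giving the lower number. Only compound 1 stands at a limit, and this step is read between two true numbers and not against that limit: the limit of > 50000 nM in this assay, at which 1 of the 4 values shown sits.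

The compounds shown do not tell why the 4-methoxyphenyl ester gives the higher number, nor whether the same change would have the same size on the core of compound 1. Also open, going by these compounds, is what fluoro, a nitrile, an amine or a carboxylic acid on this aromatic carbon would give in this assay.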